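Cytotoxicity notes: chloro added to the anilide of compound 2

The source may hold more compounds than are shown below. What is called first, only, known or untested is meant among the compounds shown, and "the series" means these compounds.

Two members of the series carry a pyridyl-thiadiazole thioether linked through an amide to an aryl group. Compound 1 `CC(Sc1nnc(-c2ccncc2)s1)C(=O)Nc1ccc(Cl)cc1Cl` has a dichlorinated anilide; compound 2 `O=C(CCSc1nnc(-c2ccncc2)s1)Nc1ccccc1` the plain anilide on a three-carbon chain.

In an ADME assay on HepG2 cells (Homo sapiens) for cytotoxicity, with a stated time of 3 days (a higher number here means that more compound is tolerated, a lower number that less compound is tolerated), compound 1 gives > 50000 nM, which is a limit of the assay rather than a number. In this assay compound 2 likewise gives > 50000 nM, again a limit and not a number. Compound 2 therefore stands at the top end of what was tested, as does the other value shown, with no ranking possible between the two.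

Compound 3 `O=C(CCSc1nnc(-c2ccncc2)s1)Nc1ccccc1Cl` differs from compound 2 in one place: chloro in place of hydrogen on an aromatic carbon. Within the data shown here, no measured step between compounds is available for this change; the expectation rests on (the limit of > 50000 nM in this assay, at which 2 of the 2 values shown sit). Among the measured compounds shown here, no change beyond the scatter is expected in this assay, since both values so far sit at the same limit.

For compound 3 the estimated value in this assay is 60000 nM, within 30000 nM to 150000 nM, most likely reported again as a limit. The expected step from compound 2 to compound 3 is a step that the limit leaves unreadable from compound 2 to compound 3.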

Compound 3, half-maximal cytotoxic concentration: > 50000 nM
Compound 3: a limit, no number (the forecaster's own chance of this, stated with the estimate: 80%); the middle value is on the limit's open side.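

No step can be read from compound 2 to compound 3 in this assay, as both compounds give a limit and not a number. The compounds shown leave open what actual value compound 1, compound 2 and compound 3 each have in this assay, and so whether chloro in place of hydrogen changes that value at all.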